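This account rests on a few compounds, and the source may have more. Where it says the series, first, only, none or still open, it means among the compounds named here.

In an assay on CHO cells for displacement of a labelled ligand from 5-hydroxytryptamine receptor 1D (Homo sapiens) (a higher number here means a weaker inhibitor, a lower number a stronger inhibitor), compound 1 `c1ccc(CC2CCN(CCCc3c[nH]c4ccc(-n5cnnc5)cc34)CC2)cc1` gives 0.3 nM, compound 2 `CN(Cc1ccccc1)C1CCN(CCCc2c[nH]c3ccc(-n4cnnc4)cc23)CC1` gives 2.1 nM, and compound 3 `FC1(Cc2ccccc2)CCN(CCCc2c[nH]c3ccc(-n4cnnc4)cc23)CC1` gives 0.9 nM. Among these three numbers compound 3 stands second highest: its nearest neighbour is compound 2, whose value is higher, and the furthest is compound 1, whose value is lower. Two single changes from compound 1 have been measured in this assay: a 7.0-fold higher number from compound 1 to compound 2 (0.85 log units; beyond the scatter), and a 3.0-fold higher number from compound 1 to compound 3 (0.48 log units; beyond the scatter).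

Compound 4 `FC1(Cc2ccccc2C(F)(F)F)CCN(CCCc2c[nH]c3ccc(-n4cnnc4)cc23)CC1` differs from compound 3 in one place: trifluoromethyl in place of hydrogen on an aromatic carbon, on an aromatic carbon of a six-membered aromatic ring of carbon only, ortho to a large group. Among the compounds with values here, none of the measured steps touches this aromatic ring; the two known steps concern the saturated ring carbon, where replacing hydrogen by fluoro or benzyl by benzyl(methyl)amino each gave a modest rise in the number. On the evidence from compounds 1, 2 and 3 there is nothing that speaks for a large movement in either direction, so the expected step from compound 3 to compound 4 is small, a 1.3-fold higher number from compound 3 to compound 4 (0.12 log units; within the scatter), and may fall within the scatter. Compound 4 is therefore estimated at 1.2 nM, with a range from 0.4 nM to 4 nM.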

Compound 4, half-maximal inhibitory concentration: 0.3 nM
For compound 4 the middle estimate is 4.0-fold (0.60 log units) above the measured one, and the stated range ends above it.
By their numbers in this assay, from the lowest: compounds 1 and 4 (each within the scatter of the next); then compound 3; then compound 2.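

In this assay, within the data shown here, the change to 2-(trifluoromethyl)benzyl gives a 3.0-fold lower number from compound 3 to compound 4 (0.48 log units; beyond the scatter), which shows that the aromatic ring of the benzyl group, a part of the molecule that no earlier step had touched, accepts trifluoromethyl on this carbon, ortho to a large group, and that the number falls there rather than rises. It is also the first single change shown that lowers the number: the two earlier steps, a 7.0-fold higher number from compound 1 to compound 2 (0.85 log units; beyond the scatter) and a 3.0-fold higher number from compound 1 to compound 3 (0.48 log units; beyond the scatter), both raised it, and both were changes on a saturated ring carbon. No measurement at hand accounts for what this group does at this place.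

The compounds shown leave open whether a methyl group, a chlorine atom or a methoxy group on the same aromatic carbon would move the number the same way, and whether trifluoromethyl on another carbon of that ring would do so too. They also leave open whether the same change would lower the number in compound 1, without the fluoro on the saturated ring carbon, or in compound 2, with its benzyl(methyl)amino group.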